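A few compounds are considered here, and "the series" means these few. Any claim that something is new, unique, unknown or untested is made for them only; others in the source may bear on it.

The set is built around one shared core. Compound 1 `O=C(O)CCC(=O)Nc1ccc(-c2nc3cc(C(F)(F)F)ccc3[nH]2)cc1` carries ((2-carboxyethyl)carbonyl)amino on an aromatic carbon, compound 2 `COc1ccc(-c2nc3cc(C(F)(F)F)ccc3[nH]2)cc1` carries methoxy in the same place, and compound 3 `CCN(CC)CC(=O)Nc1ccc(-c2nc3cc(C(F)(F)F)ccc3[nH]2)cc1`, not yet measured, carries (((diethylamino)methyl)carbonyl)amino there. In an ADME assay on MT4 cells (Homo sapiens) for cytotoxicity, read by MTT assay, with a stated time of 96 h (a higher number here means that more compound is tolerated, a lower number that less compound is tolerated), compound 1 gives only a limit, > 100000 nM. Among the compounds with values here, compound 2 gives 2000 nM in this assay, the only true number among the values shown. Within the data shown here, the one measured step, an at least 50-fold lower number from compound 1 to compound 2 (1.69 log units; beyond the scatter), is the only step bearing on this position, and it rests on (the limit of > 100000 nM in this assay, at which 1 of the 2 values shown sits), so its real size is unknown beyond the stated bound. The change to compound 3 is (((diethylamino)methyl)carbonyl)amino in place of methoxy on an aromatic carbon. It brings back an amide linkage of the kind present in compound 1 but ends in a diethylamino group rather than a carboxylic acid, so the measured step is only a loose guide. A moderate rise in tolerated concentration from compound 2 is expected, a 10-fold higher number from compound 2 to compound 3 (1.00 log units; beyond the scatter). Compound 3 is therefore estimated at 20000 nM in this assay, with a range from 3000 nM to 100000 nM.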

Compound 3, half-maximal cytotoxic concentration: 8000 nM
For compound 3 the middle estimate is 2.5-fold (0.40 log units) above the measured one; the measured number falls inside the stated range.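

Putting (((diethylamino)methyl)carbonyl)amino in place of methoxy on this aromatic carbon gives a 4.0-fold higher number from compound 2 to compound 3 (0.60 log units; beyond the scatter), so a larger amide-linked group at this position does not by itself bring the tolerated concentration up to the level of the acid-ended amide. The comparison with compound 1 keeps the amide linkage and changes only the end of the chain: diethylamino in place of carboxymethyl gives an at least 12-fold lower number from compound 1 to compound 3 (1.09 log units; beyond the scatter), which shows for these two compounds that the chain end matters in this assay, and not the amide linkage alone. That step, like the earlier one from methoxy, gives only a bound on its size and not a true difference: the limit of > 100000 nM in this assay, at which 1 of the 3 values shown sits.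

The compounds shown leave open whether a smaller amine such as dimethylamino, a ring amine such as morpholine, or a longer chain between the carbonyl and the amine would shift the number, and whether a plain acetamide with neither amine nor carboxylic acid would sit nearer compound 2 or compound 1. They also leave open how large the true gap between the two amides is.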